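A few compounds are considered here, and "the series" means these few. Any claim that something is new, unique, unknown or untested is made for them only; others in the source may bear on it.

Compound 3 `COc1ccc2nc(NC(=O)c3cn(-c4ccccc4)nc3-c3ccccc3)sc2c1` gives the highest number of the three measured compounds in a functional assay on U-87MG ATCC cells for cytotoxicity against U-87 MG (Homo sapiens), read by MTT assay, with a stated time of 72 h (on this read-out lower numbers stand for stronger inhibition and higher numbers for weaker inhibition), at 40600 nM; compound 1 `O=C(Nc1nc2ccccc2s1)c1cn(-c2ccccc2)nc1-c1ccccc1` gives 8960 nM and compound 2 `O=C(Nc1nc2ccc(Cl)cc2s1)c1cn(-c2ccccc2)nc1-c1ccccc1` gives 4980 nM. The steps are a 4.5-fold higher number from compound 1 to compound 3 (0.66 log units; beyond the scatter) and an 8.2-fold higher number from compound 2 to compound 3 (0.91 log units; beyond the scatter), while a 1.8-fold lower number from compound 1 to compound 2 (0.26 log units; within the scatter). Compound 4 `Cc1ccc2nc(NC(=O)c3cn(-c4ccccc4)nc3-c3ccccc3)sc2c1` differs from compound 3 by methyl in place of methoxy on an aromatic carbon. For the measured compounds named here, no measured step shows methyl in place of methoxy directly, but both steps that introduced the methoxy raised the number beyond the scatter, whereas hydrogen and chloro at that carbon gave numbers within the scatter of each other. A modest lowering is therefore expected for compound 4, a 3.4-fold lower number from compound 3 to compound 4 (0.53 log units; beyond the scatter). Compound 4 is estimated at 12000 nM, with a range of 5000 nM to 30000 nM.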

Compound 4, half-maximal inhibitory concentration: 23200 nM
Compound 4: middle estimate off by 1.9-fold (0.29 log units), on the low side, within the range that was stated.
By their numbers in this assay, from the lowest: compounds 2 and 1 (each within the scatter of the next); then compounds 4 and 3 (each within the scatter of the next).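

In this assay, methyl in place of methoxy at this carbon gives a 1.8-fold lower number from compound 3 to compound 4 (0.24 log units; within the scatter) and so does not separate the two groups. Methyl in place of hydrogen gives a 2.6-fold higher number from compound 1 to compound 4 (0.41 log units; beyond the scatter) and methyl in place of chloro gives a 4.7-fold higher number from compound 2 to compound 4 (0.67 log units; beyond the scatter), which shows that a higher number at this carbon is not confined to methoxy among these compounds. Nothing available here explains this grouping.

As far as these compounds go, whether an amine or a carboxylic acid at this carbon would fall with hydrogen and chloro or with methyl and methoxy remains open. A longer chain such as ethyl also remains untested in the compounds shown.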